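This account rests on a few compounds, and the source may have more. Where it says the series, first, only, none or still open, it means among the compounds named here.

compound 1 `O=S(=O)(/C=C/c1ccc(O)c(O)c1)CCC1CCCCC1`: 9800 nM
compound 2 `O=S(=O)(/C=C/c1ccc(O)c(O)c1)CC1CCCCO1`: 10800 nM

Both values come from a functional assay, read by fluorescence and spectrophotometry, with a stated time of 1 h; a lower number here means that less compound is needed, a higher number that more compound is needed for the effect. Compound 2 stands level with compound 1, and the two cannot be separated on these numbers. The next structure is compound 3 `O=S(=O)(/C=C/c1ccc(O)c(O)c1)CC1CCCO1`, with oxolan-2-yl in place of oxan-2-yl on a saturated chain carbon bound to a sulfonyl sulfur. Among the compounds with values here, only one measured step bears on this change, at the same place: a 1.1-fold higher number from compound 1 to compound 2 (0.04 log units; within the scatter). Within the data shown here, no compound with the five-membered ring has been measured yet, so that single step is thin evidence. Even so, no step beyond the scatter is expected in this assay because a 1.1-fold higher number from compound 1 to compound 2 (0.04 log units; within the scatter) is the only change seen at this place. The expected step is a 1.1-fold lower number from compound 2 to compound 3 (0.03 log units; within the scatter). For compound 3 the estimated value is 10000 nM, with an expected range of 5000 nM to 20000 nM.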

Compound 3, half-maximal effective concentration: 10500 nM
Estimate against measurement, compound 3: 1.1-fold (0.02 log units) below, and the stated range covers the measured number.
By their numbers in this assay, from the lowest: compounds 1, 3 and 2 (each within the scatter of the next).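

In this assay the size of the ring at this place makes no readable difference: oxolan-2-yl in place of oxan-2-yl gives a 1.0-fold lower number from compound 2 to compound 3 (0.01 log units; within the scatter) and leaves the two compounds level. Oxolan-2-yl in place of cyclohexylmethyl gives a 1.1-fold higher number from compound 1 to compound 3 (0.03 log units; within the scatter) and so extends this to all three compounds, which cannot be separated on a saturated chain carbon bound to a sulfonyl sulfur, whether or not the ring holds an oxygen. No measurement on hand accounts for this flat result or ties it to any property of these groups.

On these data alone, whether an amine or a carboxylic acid at this place would give a number clearly apart from these three stays open, as does the effect of a longer chain in place of oxolan-2-yl. The compounds shown all keep the shared core, so they say nothing about changes made to it.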